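The source may hold more compounds than are shown below. What is called first, only, known or untested is meant among the compounds shown, and "the series" means these compounds.

Measured so far in a functional assay on OVCAR-8 cells (Homo sapiens) for cytotoxicity, read by sulforhodamine B assay, with a stated time of 48 h, tested at 100 uM; a lower number here means a stronger effect, a higher number a weaker effect of the compound at the concentration tested:

compound 1 `COc1cc(-c2cc(/C=C/C(=O)c3ccc(N)cc3)[nH]n2)cc(OC)c1OC`, -91%
compound 2 `COc1ccc(-c2cc(/C=C/C(=O)c3ccc(OC)c(OC)c3)[nH]n2)cc1`, -66%
compound 3 `COc1cc(-c2cc(/C=C/C(=O)c3ccc(Cl)c(Cl)c3)[nH]n2)cc(OC)c1OC`, -36%

Compound 3 stands highest of the three numbers in this assay, that is, it shows the weakest effect at the concentration tested. Its nearest neighbour is compound 2, whose value lies lower and beyond the scatter; compound 1 lies furthest off, lower still and also beyond the scatter.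

The next compound, compound 4 `COc1ccc(C(=O)/C=C/c2cc(-c3cc(OC)c(OC)c(OC)c3)n[nH]2)cc1`, carries one change against compound 3: 4-methoxyphenyl in place of 3,4-dichlorophenyl on a carbonyl carbon.

Among the measured compounds shown here, only one measured step touches the same place, the one from compound 1 to compound 3, a number 55 percentage points higher from compound 1 to compound 3 (beyond the scatter), where a group with a hydrogen-bond donor on the carbonyl carbon gave way to the dichlorinated ring and the effect fell sharply. Compound 2, which carries methoxy groups on the ring attached to the carbonyl carbon, differs from compound 3 in more than one place, so its value can only be read as a loose pointer: it sits well below compound 3. For the measured compounds named here, both observations suggest that removing the dichlorinated ring in favour of the methoxy-bearing one should move the number down, beyond the scatter, though the single step is a thin basis.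

Compound 4 is therefore expected to show a step of a number 34 percentage points lower from compound 3 to compound 4 (beyond the scatter), with an estimate of -70% and a likely range from -95% to -40%.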

Compound 4, a percentage reported as activity, at one concentration (the size of the read-out at that concentration, not a potency): -16%
Compound 4: middle estimate off by 54 percentage points, on the low side; measured number above the stated range.
By their numbers in this assay, from the lowest: compound 1; then compound 2; then compound 3; then compound 4.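

At this place, on a carbonyl carbon, the methoxy-bearing ring does not recover the effect lost with the 3,4-dichlorophenyl group: in this assay the number moves further up, a number 20 percentage points higher from compound 3 to compound 4 (beyond the scatter), and the full span of this place now shows as a number 75 percentage points higher from compound 1 to compound 4 (beyond the scatter), with the change there being methoxy in place of amino on an aromatic carbon. Among compound 1, compound 3 and compound 4, which differ only in this group, the amino compound therefore stands alone at the low end, and the low number of compound 2 gives no guide to methoxy groups here, since that compound differs from compound 4 in more than one place. No measurement on hand explains why these groups fall in this order.

Still open, going by these compounds, is whether the effect of compound 1 is tied to the amino group itself or would persist with a hydroxyl or dimethylamino group in its place. Also open, on these data alone, is how much the ring on the far side of the core contributes, as only compound 2 varies there, together with other changes.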